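Fluoro for Chloro on the Pyridine of a Fused Triazole

The source may report more compounds than this note shows. Statements on the series, on what has been measured and on what is new or still open speak of the compounds shown alone.

Measured so far:
Compound 1 `COc1ccc(Cl)c(-c2nnc3sc(-c4ccnc(Cl)c4)nn23)c1` gives 20.2% in a functional assay on the whole organism (strain Wistar Albino) for inhibition, with Rattus norvegicus as the target, read by paw edema, with a stated time of 2 h, at a dose of 20 mg/kg; a lower number here means less inhibition, a higher number more inhibition at the dose given (going by the name of the read-out).
Compound 2 `Cc1occc1-c1nnc2sc(-c3ccnc(Cl)c3)nn12` gives 15.3% in this assay.
Compound 3 `COc1ccc(Cl)c(-c2nnc3sc(-c4ccnc(F)c4)nn23)c1` gives 24.7% in this assay.

Compound 1 and compound 3 share one core and differ in one place: fluoro in place of chloro on an aromatic carbon. This step moves the read-out a number 4.5 percentage points higher from compound 1 to compound 3 (within the scatter). Compound 2 carries a different core; the difference between the two cores is not broken down here. Its value and that of compound 1 sit close together, as do its value and that of compound 3.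

Compound 4 `Cc1occc1-c1nnc2sc(-c3ccnc(F)c3)nn12` is not yet measured. It stands to compound 2 as compound 3 stands to compound 1, and the change is the same: fluoro in place of chloro on an aromatic carbon. The place around the change is described in the same words for both pairs, so the two changes are the same kind of change made at the same kind of site.

Because the step from compound 1 to compound 3 was a number 4.5 percentage points higher from compound 1 to compound 3 (within the scatter), compound 4 is expected to move by a step of about a number 4.2 percentage points higher from compound 2 to compound 4 (within the scatter) from compound 2. On that basis compound 4 is estimated to reach about 19.5%, with a likely range from 10% to 30%.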

Compound 4, a percentage reported as inhibition, in the whole organism at one dose (the size of the read-out at that dose, not a potency): 18.2%
Estimate against measurement, compound 4: 1.3 percentage points above, and the stated range covers the measured number.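

Carried to the second core, fluoro in place of chloro gives a number 2.9 percentage points higher from compound 2 to compound 4 (within the scatter) in this assay. Set beside the earlier step, the same change on an aromatic carbon of the pyridine ring gives steps that agree on these two cores: the same change on two cores in this assay, a number 4.5 percentage points higher (within the scatter) from compound 1 to compound 3 and a number 2.9 percentage points higher (within the scatter) from compound 2 to compound 4, 1.6 percentage points apart, within the scatter of two such steps. This agreement does not show that the change moves the read-out at all, as each step on its own lies within the scatter, and two cores cannot establish a rule for the whole series.

The compounds shown carry only chloro or fluoro at this place, which leaves open whether an amine or a nitrile there would give a step that stands clear of the scatter. They also leave open whether the small step seen here would hold on a third core, or at another dose or time in the same kind of paw edema test.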